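Moving one chlorine on compound 3

A few compounds are considered here, and "the series" means these few. Any claim that something is new, unique, unknown or untested is made for them only; others in the source may bear on it.

Measured so far in a functional assay on MT4 cells (Homo sapiens) for cytotoxicity (on this read-out higher numbers stand for lower toxicity in this test and lower numbers for higher toxicity in this test), are three compounds:
- compound 1 `Cc1nc(S)n(Nc2ccc(F)cc2)c1-c1ccccc1` (220000 nM)
- compound 2 `Cc1nc(S)n(Nc2cccc(Cl)c2)c1-c1cccc(Cl)c1` (31000 nM)
- compound 3 `Cc1nc(S)n(Nc2cccc(Cl)c2)c1-c1ccccc1` (66700 nM)

Compound 3 stands in the middle of these three numbers, second highest, above compound 2 and below compound 1. The next molecule is compound 4 `Cc1nc(S)n(Nc2ccc(Cl)cc2)c1-c1ccccc1` and it differs from compound 3 by a single swap 4-chlorophenyl in place of 3-chlorophenyl on a nitrogen on an aromatic ring in which 4-chlorophenyl takes the place of 3-chlorophenyl on a nitrogen on an aromatic ring.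

Among the compounds with values here, no measured pair shows this swap alone. The closest evidence is a 3.3-fold lower number from compound 1 to compound 3 (0.52 log units; beyond the scatter) where 3-chlorophenyl replaces 4-fluorophenyl at that same place, a modest step that also exchanges one halogen for another. The other measured step is a 2.2-fold higher number from compound 2 to compound 3 (0.33 log units; beyond the scatter) where hydrogen replaces chloro on an aromatic carbon. It is also modest, but it lies at a different place and says little here.

Both steps are small, so only a small change is expected in this assay and none clearly beyond the scatter. Any drift should be towards a higher number, since compound 1 with 4-fluorophenyl gives 220000 nM in the same test. The expected step is a 1.3-fold higher number from compound 3 to compound 4 (0.13 log units; within the scatter) and it remains an estimate. The estimate for compound 4 is 90000 nM with 35000 nM and 220000 nM as the expected lower and upper ends.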

Compound 4, half-maximal cytotoxic concentration: 134000 nM
Compound 4: the middle estimate sits 1.5-fold (0.17 log units) below what was measured; measured number inside the range.
By their numbers in this assay, from the lowest: compound 2; then compounds 3, 4 and 1 (each within the scatter of the next, the first and the last beyond it).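

In this assay, moving the chlorine so that 4-chlorophenyl takes the place of 3-chlorophenyl on the nitrogen gives a 2.0-fold higher number from compound 3 to compound 4 (0.30 log units; within the scatter), and chloro in place of fluoro on an aromatic carbon gives a 1.6-fold lower number from compound 1 to compound 4 (0.22 log units; within the scatter); neither single change can be told apart from the normal variation between repeat measurements. Within the data shown here, this is new, since the earlier 3.3-fold lower number from compound 1 to compound 3 (0.52 log units; beyond the scatter) changed both the halogen and its place on the ring at once, and only that combined step lies beyond the scatter, while each of the two single changes taken alone does not. Nothing measured here explains these numbers.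

The compounds shown carry only halogens on this ring, so it remains open whether a methoxy group, an amine or a carboxylic acid in the same place would keep the number in this range. On these data alone, it is also open whether 4-chlorophenyl on the nitrogen would combine with a chloro on the other phenyl ring as 3-chlorophenyl does in compound 2, which gives 31000 nM.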